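The source may hold more compounds than are shown below. What is called first, only, known or untested is meant among the compounds shown, and "the series" means these compounds.

Measured compounds in an assay on membranes from CHO cells for displacement of a labelled ligand from adenosine receptor A1 (Homo sapiens), read by scintillation counting, with a stated time of 60 min, tested at 1 uM; on this read-out higher numbers stand for more inhibition at the one concentration tested (going by the name of the read-out) and lower numbers for less inhibition:
compound 1, `CC1=C(C(=O)SC(C)C)C(c2ccoc2)NC(=O)N1`, gives 9%
compound 2, `CC1=C(C(=O)OC2CCC2)C(c2ccco2)NC(=O)N1`, gives 19%

Within this small set compound 2 is not set apart: its value and that of compound 1 sit within the scatter of each other, so neither stands out. Compound 3, `CC1=C(C(=O)OC2CCC2)C(c2ccoc2)NC(=O)N1`, is unmeasured. It differs from compound 2 only in furan-3-yl in place of furan-2-yl on a saturated ring carbon. Among the measured compounds shown here, no step between measured compounds isolates this change, so no direction beyond the scatter is expected in this assay; the step is estimated at a number 5 percentage points lower from compound 2 to compound 3 (within the scatter). For compound 3 the value is expected near 14%, between 2% and 30%.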

Compound 3, a percentage reported as inhibition, at one concentration (the size of the read-out at that concentration, not a potency): 20%
For compound 3 the middle estimate is 6 percentage points below the measured one, within the range that was stated.
By their numbers in this assay, from the lowest: compounds 1, 2 and 3 (each within the scatter of the next, the first and the last beyond it).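

In this assay, furan-3-yl in place of furan-2-yl on the saturated ring carbon leaves the read-out within the scatter (a number 1 percentage points higher from compound 2 to compound 3 (within the scatter)), so the two furan attachments are not told apart here. Cyclobutyloxy in place of isopropylsulfanyl on the carbonyl carbon gives the first step beyond the scatter, though a modest one (a number 11 percentage points higher from compound 1 to compound 3 (beyond the scatter)). No measurement at hand accounts for either step.

Going by these compounds, the ester and thioester linkage and the cyclobutyl and isopropyl groups change together in that step, so their separate contributions stay open. Also open, on these data alone, is how a phenyl or a pyridine would read in place of the furan.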